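From 3-fluorophenyl to 2-bromophenyl at the assay limit

The source may report more compounds than this note shows. Statements on the series, on what has been measured and on what is new or still open speak of the compounds shown alone.

In a functional assay on HEK293 cells (Homo sapiens) for cytotoxicity (on this read-out lower numbers stand for higher toxicity in this test and higher numbers for lower toxicity in this test), compound 1 `COc1ccc([C@H]2CC(=O)N(c3cccc(C(F)(F)F)c3)C2)cc1OC1CCCC1` gives > 10000 nM as a limit of the assay, not a number. Compound 2 `COc1ccc([C@H]2CC(=O)N(c3cccc(NCc4ccoc4)c3)C2)cc1OC1CCCC1` gives > 10000 nM as a limit too. Compound 3 `COc1ccc([C@H]2CC(=O)N(c3cccc(NS(=O)(=O)c4cccc(F)c4)c3)C2)cc1OC1CCCC1` gives > 10000 nM as a limit as well, so it has no exact number. All the data so far rest on the limit of > 10000 nM in this assay, at which 3 of the 3 values shown sit, and nothing firmer.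

Compound 4 `COc1ccc([C@H]2CC(=O)N(c3cccc(NS(=O)(=O)c4ccccc4Br)c3)C2)cc1OC1CCCC1` has 2-bromophenyl in place of 3-fluorophenyl on a sulfonyl sulfur, with 2-bromophenyl in place of 3-fluorophenyl on a sulfonyl sulfur as the full count of the change. For the measured compounds named here, two measured steps bear on this place, a step that the two limits leave unreadable from compound 1 to compound 3 and a step that the two limits leave unreadable from compound 2 to compound 3 and neither has a size that can be read. Very different groups in compounds 1, 2 and 3 all ended at the limit, so no change beyond the usual scatter is expected. The expected move is a step that the limit leaves unreadable from compound 3 to compound 4 as an estimate only. Compound 4 is expected near 12000 nM with an estimated range from 5000 nM to 30000 nM and will most likely be reported as a limit again.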

Compound 4, half-maximal cytotoxic concentration: > 10000 nM
Compound 4 was reported as a limit (the forecaster's own chance of this, stated with the estimate: 85%); the middle value is on the limit's open side.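

The steps from compound 1, compound 2 and compound 3 to compound 4 cannot be read, because each of them rests on a limit of the assay, not a number: the limit of > 10000 nM in this assay, at which 4 of the 4 values shown sit.

From the compounds shown here alone, how far apart these compounds truly lie in this assay stays open, as does which change, if any, would give an exact value.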